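Acylating the aryl amine of compound 2: expected outcome

The compounds below may be only part of what the source reports. "The series", "measured", "known", "first", "only" and "open" are said of these compounds alone.

Compound 1 `COc1cc(/C=C/C(=O)c2cccc(NC(=O)c3cc(Cl)cc(Cl)c3)c2)ccc1O` gives > 50 ug/mL in a functional assay on U-87MG ATCC cells (Homo sapiens) for inhibition (on this read-out lower numbers stand for stronger inhibition and higher numbers for weaker inhibition), a limit rather than a number.
Compound 2 `COc1cc(/C=C/C(=O)c2cccc(N)c2)ccc1O` gives 7.71 ug/mL in this assay.
Compound 3 `COc1cc(/C=C/C(=O)c2cccc(NC(=O)c3ccccc3)c2)ccc1O` is not yet measured in this assay.

Compound 2 carries the only number shown in this assay; the other value is a limit. The change from compound 2 to compound 3 is benzoyl in place of hydrogen on a nitrogen on an aromatic ring. For the measured compounds named here, the single measured step that bears on it runs the other way: an at least 6.4-fold lower number from compound 1 to compound 2 (0.81 log units; beyond the scatter). Compound 1 sits at the limit of > 50 ug/mL in this assay, at which 1 of the 2 values shown sits. Restoring an acyl group on that nitrogen, here benzoyl, is therefore expected to raise the number, and the step of a 5.2-fold higher number from compound 2 to compound 3 (0.72 log units; beyond the scatter) is the expected size. Compound 3 is estimated at 40 ug/mL, within 12 ug/mL to 120 ug/mL, with a fair chance that only a limit is reported.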

Compound 3, half-maximal inhibitory concentration: 8.82 ug/mL
For compound 3 the middle estimate is 4.5-fold (0.66 log units) above the measured one; measured number below the stated range.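

In this assay, benzoyl in place of hydrogen on the nitrogen gives a 1.1-fold higher number from compound 2 to compound 3 (0.06 log units; within the scatter), so acylation of this nitrogen does not by itself raise the number. The change that matters among the compounds shown lies further out on the acyl group: phenyl in place of 3,5-dichlorophenyl on a carbonyl carbon gives an at least 5.6-fold lower number from compound 1 to compound 3 (0.75 log units; beyond the scatter). The value of compound 1 is a limit: the limit of > 50 ug/mL in this assay, at which 1 of the 3 values shown sits.

Still open, on these data alone, is whether a single chlorine on the phenyl ring of the benzoyl group is enough to raise the number. Also open, as far as these compounds go, is whether a smaller acyl group such as acetyl on the same nitrogen matches compound 2 and compound 3.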